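A few compounds are considered here, and "the series" means these few. Any claim that something is new, unique, unknown or untested is made for them only; others in the source may bear on it.

Of the compounds shown here, two from this series have been tested in a functional assay on MDA-MB-435 cells (Homo sapiens) for inhibition, read by sulforhodamine B assay, with a stated time of 48 h, tested at 10 uM; on this read-out higher numbers stand for a weaker effect at the one concentration tested and lower numbers for a stronger effect. Compound 1 `COc1cc(Cl)cc(-c2nn(-c3cccc(NC(=O)Nc4ccc(Cl)c(C(F)(F)F)c4)c3)cc2-c2ccncc2)c1` gives -16.8% in this assay, while compound 2 `COc1cc(Cl)cc(-c2nn(-c3cccc(NC(=O)Nc4cccc(C(F)(F)F)c4)c3)cc2-c2ccncc2)c1` gives -20.9%. The only difference between them is hydrogen in place of chloro on an aromatic carbon, and that step, a number 4.1 percentage points lower from compound 1 to compound 2 (within the scatter), leaves the two numbers within the scatter of each other, so compound 2 stands level with compound 1 in this assay.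

Compound 3 `COc1cc(Cl)cc(-c2nn(-c3cccc(NC(=O)c4cccc(C(F)(F)F)c4)c3)cc2-c2ccncc2)c1` is the next compound, not yet measured. It differs from compound 2 by 3-(trifluoromethyl)phenyl in place of (3-(trifluoromethyl)phenyl)amino on a carbonyl carbon. Within the data shown here, no measured step touches the carbonyl carbon or its neighbours, so the single step known, from compound 1 to compound 2, offers no guide to the direction of this change. With nothing to point either way, the expectation for compound 3 is a step in this assay of a number 10.9 percentage points higher from compound 2 to compound 3 (beyond the scatter), not beyond the scatter. The estimate for compound 3 is therefore -10%, within a range from -35% to 15%.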

Compound 3, a percentage reported as activity, at one concentration (the size of the read-out at that concentration, not a potency): 65.6%
Estimate against measurement, compound 3: 75.6 percentage points below; measured number above the stated range.
By their numbers in this assay, from the lowest: compounds 2 and 1 (each within the scatter of the next); then compound 3.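

The amino link on the carbonyl carbon turns out to matter greatly in this assay: setting the 3-(trifluoromethyl)phenyl group directly on that carbon gives a number 86.5 percentage points higher from compound 2 to compound 3 (beyond the scatter) and so a much weaker effect. The step with the chlorinated partner, a number 82.4 percentage points higher from compound 1 to compound 3 (beyond the scatter), runs the same way and is also large, whereas the earlier chloro change stayed within the scatter, so this position is far less forgiving of change than the chloro position. What lies behind this large loss cannot be said from the data available here.

The amino group leaves with its hydrogen-bond donor, so a methylamino or a methylene link on the carbonyl carbon could help separate the role of that hydrogen from that of the link. Going by these compounds, whether chloro matters once the amino link is gone also stays open.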